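The source may report more compounds than this note shows. Statements on the series, on what has been measured and on what is new or still open speak of the compounds shown alone.

Two labdane-type acids and an ester were examined in a functional assay on SMMC-7721 cells (Homo sapiens) for cytotoxicity, read by MTT assay, with a stated time of 48 h; on this read-out lower numbers stand for stronger inhibition and higher numbers for weaker inhibition. For the measured compounds named here, compound 1, `C=CC(=C)CC[C@@H]1[C@@]2(C)CCC[C@](C)(COC(=O)/C=C/c3ccc(O)cc3)[C@@H]2CC[C@@]1(C)O`, is the only one of the measured pair to give a number: in this assay compound 1 gives 15500 nM. Compound 2, `C=C1CC[C@@H]2[C@](C)(CCC[C@]2(C)C(=O)O)[C@H]1CC/C(C)=C/CO`, stands at the limit of the assay: in this assay compound 2 gives > 40000 nM, which is a limit and not a measured number. (the limit of > 40000 nM in this assay, at which 1 of the 2 values shown sits), so compound 2 is the weaker of the two on the numbers shown, and how far beyond the limit it lies is not known.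

The step followed here leads from compound 2 to compound 3, `C=C[C@@](C)(O)CC[C@H]1C(=C)CC[C@@H]2[C@]1(C)CCC[C@]2(C)C(=O)O`. The two compounds share every atom and differ only in how the side chain is joined: 1-hydroxy-1-methylprop-2-en-1-yl in place of 3-hydroxy-1-methylprop-1-en-1-yl on a saturated chain carbon, two bonds along the chain from a saturated ring carbon. No measured step of this kind exists among the compounds shown, so there is nothing to anchor the size of the change. Because compound 2 sits at > 40000 nM, the step of a number no higher from compound 2 to compound 3 (the limit leaves the size open) is expected to be small, with no clear direction beyond the scatter. Compound 3 is therefore estimated at 40000 nM, within a range from 20000 nM to 80000 nM.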

Compound 3, half-maximal inhibitory concentration: > 40000 nM
Compound 3 gave a limit, no number (the forecaster's own chance of this, stated with the estimate: 60%); the middle value sits exactly at the limit.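

For the compounds shown here, compound 3, like compound 2, gives only a limit in this assay, so no step between compound 2 and compound 3 can be read: the limit of > 40000 nM in this assay, at which 2 of the 3 values shown sit. The compounds shown leave open how far beyond that limit compound 2 and compound 3 lie, and so whether 1-hydroxy-1-methylprop-2-en-1-yl in place of 3-hydroxy-1-methylprop-1-en-1-yl changes the read-out at all.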